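Lengthening the Chain on the Ring Nitrogen

The source may hold more compounds than are shown below. What is called first, only, known or untested is meant among the compounds shown, and "the series" means these compounds.

Three compounds sharing one core were measured in a functional assay on A549 cells (Homo sapiens) for antiproliferative activity, read by MTT assay, with a stated time of 48 h; on this read-out higher numbers stand for weaker inhibition of growth and lower numbers for stronger inhibition of growth:
compound 1, `Cc1ccc(-c2cnc(N(Cc3ccccc3)Cc3ccc(C(=O)NO)cc3)s2)cc1`, gives 4410 nM;
compound 2, `CCN(Cc1ccc(C(=O)NO)cc1)c1ncc(-c2ccc(C)cc2)s1`, gives 2700 nM;
compound 3, `CCCCCCCCN(Cc1ccc(C(=O)NO)cc1)c1ncc(-c2ccc(C)cc2)s1`, gives 4630 nM.

Compound 2 has the lowest of the three numbers, yet both others sit within the scatter of it: a 1.6-fold lower number from compound 1 to compound 2 (0.21 log units; within the scatter) and a 1.7-fold higher number from compound 2 to compound 3 (0.23 log units; within the scatter). Compound 4, `CCCN(Cc1ccc(C(=O)NO)cc1)c1ncc(-c2ccc(C)cc2)s1`, differs from compound 2 by methyl in place of hydrogen on a saturated chain carbon, two bonds along the chain from a nitrogen on an aromatic ring. Going by the values given here, the steps that bear on this are the chain changes bound to a nitrogen on an aromatic ring, a 1.7-fold higher number from compound 2 to compound 3 (0.23 log units; within the scatter) and a 1.0-fold higher number from compound 1 to compound 3 (0.02 log units; within the scatter), both within the scatter. Adding a single carbon is therefore expected to move the number little, and the expected step is a 1.1-fold higher number from compound 2 to compound 4 (0.05 log units; within the scatter). Compound 4 is estimated to give 3000 nM, with a range from 1500 nM to 6000 nM.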

Compound 4, concentration for 50% growth inhibition: 3310 nM
Estimate against measurement, compound 4: 1.1-fold (0.04 log units) below, within the range that was stated.
By their numbers in this assay, from the lowest: compounds 2, 4, 1 and 3 (each within the scatter of the next).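

In this assay, methyl in place of hydrogen at this chain carbon gives a 1.2-fold higher number from compound 2 to compound 4 (0.09 log units; within the scatter), so this one-carbon extension, ethyl to propyl, produces no change that can be told from the scatter. The comparisons with the other two compounds read the same way, with a 1.4-fold lower number from compound 3 to compound 4 (0.15 log units; within the scatter) and a 1.3-fold lower number from compound 1 to compound 4 (0.12 log units; within the scatter), so all four compounds remain within the scatter of the next in this series. No evidence is available to explain this result.

The compounds shown leave open whether an amine or a carboxylic acid on this chain would move the number beyond the scatter.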